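The source may report more compounds than this note shows. Statements on the series, on what has been measured and on what is new or still open speak of the compounds shown alone.

In a functional assay on MDA-MB-435 cells (Homo sapiens) for cytotoxicity, read by MTT assay, with a stated time of 72 h (a lower number here means a stronger inhibitor, a higher number a weaker inhibitor), compound 3 `N[C@H]1CC[C@H](Nc2c(C(=O)NCc3ccccn3)nc(Br)c3cccnc23)CC1` gives 4000 nM, level with compound 1 `CN(C)c1ccc(CNC(=O)c2nc(Br)c3cccnc3c2N[C@H]2CC[C@H](N)CC2)cc1` at 4000 nM. Compound 2 `COC(=O)c1nc(Br)c2cccnc2c1N[C@H]1CC[C@H](N)CC1` reports only a limit of the assay, > 20000 nM.

Compound 4 `N[C@H]1CC[C@H](Nc2c(C(=O)NC3CCCCC3)nc(Br)c3cccnc23)CC1` keeps the shared core of compound 3 and differs at one place: cyclohexyl in place of (pyridin-2-yl)methyl on an amide-type nitrogen. In words, cyclohexyl stands in place of (pyridin-2-yl)methyl on an amide-type nitrogen.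

Among the measured compounds shown here, two measured steps bear on this change. The nearer is no change at the digits printed from compound 1 to compound 3 (within the scatter), where pyridin-2-yl replaced 4-(dimethylamino)phenyl on the group carried by the amide-type nitrogen. That swap left the number within the scatter. The other is an at least 5.0-fold lower number from compound 2 to compound 3 (0.69 log units; beyond the scatter), where ((pyridin-2-yl)methyl)amino replaced methoxy on a carbonyl carbon. Compound 4 keeps an amide-type nitrogen, so the gain seen in an at least 5.0-fold lower number from compound 2 to compound 3 (0.69 log units; beyond the scatter) is expected to hold. For the measured compounds named here, only one swap of this kind has been measured, and it did not replace the aromatic ring with a non-aromatic one, so the range stays wide.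

The expected size is no change at the digits printed from compound 3 to compound 4 (within the scatter), with no move beyond the scatter. Compound 4 is estimated at 4000 nM, with an expected range of 1500 nM to 12000 nM.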

Compound 4, half-maximal inhibitory concentration: > 10000 nM
Compound 4 was reported as a limit; the forecaster's own chance of this, stated with the estimate: 12%; middle value at least 2.5-fold (0.39 log units) away from the limit.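

The result for compound 4 is a limit and not a number: the limit of > 10000 nM in this assay, at which 1 of the 4 values shown sits. Even so, cyclohexyl on the amide-type nitrogen gives an at least 2.5-fold higher number from compound 3 to compound 4 (0.39 log units; beyond the scatter), and in place of 4-(dimethylamino)benzyl it gives an at least 2.5-fold higher number from compound 1 to compound 4 (0.39 log units; beyond the scatter). Among the compounds shown here, the earlier swap, which kept an aromatic ring on this group, gave no change at the digits printed from compound 1 to compound 3 (within the scatter), so a non-aromatic ring of carbon only provides the first step on this nitrogen that lies beyond the scatter.

On these data alone, the step from compound 2 to compound 4 joins two limits and cannot be read, and the distance of compound 4 beyond its limit remains unknown. As far as these compounds go, whether the aromatic ring, its nitrogen or the chain carbon matters most stays open, and a plain benzyl or a cyclohexylmethyl group on the same nitrogen would help to separate these.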